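Dichlorophenyl isomers in the amide series

The source may hold more compounds than are shown below. What is called first, only, known or untested is meant among the compounds shown, and "the series" means these compounds.

Measured in a functional assay on Vero cells (Chlorocebus sabaeus) for inhibition (a higher number here means a weaker inhibitor, a lower number a stronger inhibitor), so far:
compound 1 `COc1cc(/C=C/C(=O)c2cccc(NC(=O)c3ccc(Cl)cc3)c2)ccc1O` gives 3.82 ug/mL
compound 2 `COc1cc(/C=C/C(=O)c2cccc(NC(=O)c3ccco3)c2)ccc1O` gives 3.11 ug/mL
compound 3 `COc1cc(/C=C/C(=O)c2cccc(NC(=O)c3ccc(Cl)cc3Cl)c2)ccc1O` gives 27.2 ug/mL

Compound 3 has the highest number of the three and is the weakest inhibitor here, with a 7.1-fold higher number from compound 1 to compound 3 (0.85 log units; beyond the scatter) and an 8.7-fold higher number from compound 2 to compound 3 (0.94 log units; beyond the scatter) as its steps. Compound 4 `COc1cc(/C=C/C(=O)c2cccc(NC(=O)c3ccc(Cl)c(Cl)c3)c2)ccc1O` carries 3,4-dichlorophenyl in place of 2,4-dichlorophenyl on a carbonyl carbon and has the same atoms, joined differently. The nearest measured change is chloro in place of hydrogen on an aromatic carbon, which gave the large step above. For the measured compounds named here, the exchange of furan-2-yl for 4-chlorophenyl gave only a 1.2-fold lower number from compound 1 to compound 2 (0.09 log units; within the scatter) and so sets no size for a step. Going by the values given here, no measured compound carries 3,4-dichlorophenyl, so it remains open whether the rise at compound 3 follows the added chloro or its placement. A partial return towards compound 1 is expected, to a lower number. The expected step is a 3.0-fold lower number from compound 3 to compound 4 (0.48 log units; beyond the scatter) as a rough estimate. Compound 4 is estimated at 9 ug/mL within an expected range of 3 ug/mL to 26 ug/mL in this assay for now.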

Compound 4, half-maximal inhibitory concentration: > 50 ug/mL
Compound 4: only a limit was reported; the forecaster's own chance of this, stated with the estimate: 3%; middle value at least 5.5-fold (0.74 log units) away from the limit.
By their numbers in this assay, from the lowest: compounds 2 and 1 (each within the scatter of the next); then compound 3. At a limit, above all of these: compound 4.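

The second chloro raises the number in this assay in both placements, with a 7.1-fold higher number from compound 1 to compound 3 (0.85 log units; beyond the scatter) and an at least 13-fold higher number from compound 1 to compound 4 (1.11 log units; beyond the scatter), so the rise at compound 3 is not tied to the 2,4-dichlorophenyl pattern alone. The furan-2-yl amide gives the same picture, with an at least 16-fold higher number from compound 2 to compound 4 (1.20 log units; beyond the scatter). With an at least 1.8-fold higher number from compound 3 to compound 4 (0.26 log units; that floor lies within the scatter), the order of the two dichlorophenyl isomers stays unsettled, and compound 4 reads only as a limit: the limit of > 50 ug/mL in this assay, at which 1 of the 4 values shown sits.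

The compounds shown leave open whether the rise belongs to chloro as such or to any second group on the ring, a question that methoxy or an amine in place of the second chloro would address. They also leave open how far compound 4 actually lies from compound 3.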